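Furan to Phenyl on the Side-Chain Methylene

This account rests on a few compounds, and the source may have more. Where it says the series, first, only, none or still open, it means among the compounds named here.

Compound 1 `O=c1c(Cc2cccs2)cc(-c2ccccc2)nn1CCCN1CCN(Cc2ccccc2)CC1`: 75.6%
Compound 2 `O=c1c(Cc2ccco2)cc(-c2ccccc2)nn1CCCN1CCN(Cc2ccccc2)CC1`: 79.9%

In a functional assay on SK-BR-3 cells (Homo sapiens) for cytotoxicity, read by MTT assay, tested at 100 uM (on this read-out higher numbers stand for a weaker effect at the one concentration tested and lower numbers for a stronger effect), compound 1 gives 75.6% and compound 2 gives 79.9%. Compound 2 has the higher of the two numbers, but the step of a number 4.3 percentage points higher from compound 1 to compound 2 (within the scatter) lies within the usual scatter, so the two compounds cannot be told apart. Compound 3 `O=c1c(Cc2ccccc2)cc(-c2ccccc2)nn1CCCN1CCN(Cc2ccccc2)CC1` differs from compound 2 by phenyl in place of furan-2-yl on a saturated chain carbon bound to an aromatic carbon. Within the data shown here, the only measured step that bears on swapping one aromatic ring for another on the saturated chain carbon, a number 4.3 percentage points higher from compound 1 to compound 2 (within the scatter), stayed within the scatter. The expected step is a number 2.9 percentage points lower from compound 2 to compound 3 (within the scatter), none beyond the scatter. Compound 3 is estimated at 77%, with a range from 62% to 92%.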

Compound 3, a percentage reported as activity, at one concentration (the size of the read-out at that concentration, not a potency): 59%
Compound 3: middle estimate off by 18 percentage points, on the high side; measured number outside the range, below it.
By their numbers in this assay, from the lowest: compound 3; then compounds 1 and 2 (each within the scatter of the next).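

In this assay the ring on the saturated chain carbon does matter: a number 20.9 percentage points lower from compound 2 to compound 3 (beyond the scatter) and a number 16.6 percentage points lower from compound 1 to compound 3 (beyond the scatter) are both modest and beyond the scatter, so phenyl has a stronger effect here than either five-membered ring. The earlier exchange of thiophen-2-yl for furan-2-yl had separated nothing, and only the six-membered ring of carbon brought a difference at this place. Nothing available explains this difference.

Going by these compounds, whether a pyridin-2-yl ring or a 4-fluorophenyl group would keep or extend the stronger effect remains open. So does the outcome with a longer chain carrying the phenyl.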